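Para substituent on the benzylidene ring: hydroxy to dimethylamino

A few compounds are considered here, and "the series" means these few. Any claim that something is new, unique, unknown or untested is made for them only; others in the source may bear on it.

Compound 1 `CC1=CC[C@@H]([C@@](C)(O)CCCC(C)(C)NC(=S)N/N=C\c2ccccc2)CC1`: 28700 nM
Compound 2 `COc1ccc(/C=N\NC(=S)NC(C)(C)CCC[C@](C)(O)[C@@H]2CC=C(C)CC2)cc1`: 94900 nM
Compound 3 `CC1=CC[C@@H]([C@@](C)(O)CCCC(C)(C)NC(=S)N/N=C\c2ccc(O)cc2)CC1`: 21200 nM

Values come from a functional assay on MCF7 cells (Homo sapiens) for cytotoxicity, read by sulforhodamine B assay; on this read-out lower numbers stand for stronger inhibition of growth and higher numbers for weaker inhibition of growth. Compound 3 gives the lowest of the three numbers; compound 1 sits within the scatter of it (a 1.4-fold lower number from compound 1 to compound 3 (0.13 log units; within the scatter)), while compound 2 lies beyond it (a 4.5-fold lower number from compound 2 to compound 3 (0.65 log units; beyond the scatter)). Compound 4 `CC1=CC[C@@H]([C@@](C)(O)CCCC(C)(C)NC(=S)N/N=C\c2ccc(N(C)C)cc2)CC1` differs from compound 3 by dimethylamino in place of hydroxy on an aromatic carbon. Within the data shown here, no measured step covers this exact change. The closest is the methoxy step, a 3.3-fold higher number from compound 1 to compound 2 (0.52 log units; beyond the scatter), where a para group without a donor gave a higher number, and its reversal, a 4.5-fold lower number from compound 2 to compound 3 (0.65 log units; beyond the scatter). Dimethylamino likewise carries no donor, so a modestly higher number is expected for compound 4, a 1.9-fold higher number from compound 3 to compound 4 (0.28 log units; within the scatter). Compound 4 is estimated at 40000 nM, range 15000 nM to 110000 nM.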

Compound 4, concentration for total growth inhibition: > 100000 nM
Compound 4 was reported as a limit (the forecaster's own chance of this, stated with the estimate: 10%); middle value at least 2.5-fold (0.39 log units) from the limit.
By their numbers in this assay, from the lowest: compounds 3 and 1 (each within the scatter of the next); then compound 2. At a limit, above all of these: compound 4.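

In this assay compound 4 gives only a limit, > 100000 nM. Even so, dimethylamino on this aromatic carbon stands clearly apart from hydroxy, an at least 4.7-fold higher number from compound 3 to compound 4 (0.67 log units; beyond the scatter), and from hydrogen, an at least 3.4-fold higher number from compound 1 to compound 4 (0.54 log units; beyond the scatter), so the position is less tolerant than compounds 1 and 3 alone suggested. Against methoxy the step reads an at least 1.0-fold higher number from compound 2 to compound 4 (0.02 log units; that floor lies within the scatter), which leaves methoxy and dimethylamino unordered.

Going by these compounds, whether a hydrogen-bond donor matters here stays open: compound 1 carries none on this carbon, yet lies within the scatter of compound 3. On these data alone, how a primary amino group or a carboxylic acid on the same carbon would read is also open.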